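The compounds below may be only part of what the source reports. "The series", "measured", "known", "first", "only" and "open" are said of these compounds alone.

Measured compounds:
- compound 1 `CN(C)CCn1cnnc1-c1cc(Oc2ccc(NC(=O)Nc3ccc(F)c(F)c3)cc2F)ccn1` — in a functional assay on HT-29 cells (Homo sapiens) for antiproliferative activity, read by MTT assay, with a stated time of 72 h (a lower number here means a stronger inhibitor, a higher number a weaker inhibitor), compound 1 gives 3620 nM
- compound 2 `CCN(CC)CCn1cnnc1-c1cc(Oc2ccc(NC(=O)Nc3ccc(F)c(F)c3)cc2F)ccn1` — compound 2 gives 1240 nM
- compound 3 `CN(C)CCCn1cnnc1-c1cc(Oc2ccc(NC(=O)Nc3cccc(C(F)(F)F)c3)cc2F)ccn1` — compound 3 gives 980 nM

Compound 3 has the lowest number of the three. Its gap to compound 2 is within the scatter, so the two cannot be ordered; only its gap to compound 1 is beyond the scatter, so compound 3 cannot be called the strongest of the set.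

Compound 4 `CN(C)CCCn1cnnc1-c1cc(Oc2ccc(NC(=O)Nc3ccc(F)c(F)c3)cc2F)ccn1` is to be measured in this assay. It differs from compound 3 in one place: 3,4-difluorophenyl in place of 3-(trifluoromethyl)phenyl on an amide-type nitrogen. Among the measured compounds shown here, the new aryl group is the one already carried by compound 1 and compound 2, but no measured pair isolates this aryl exchange on an otherwise fixed scaffold. For the measured compounds named here, the only measured step, a 2.9-fold lower number from compound 1 to compound 2 (0.47 log units; beyond the scatter), concerns the amine on the chain and does not bear on the urea aryl group. The comparison of compound 3 with compound 1 and compound 2 mixes the aryl change with a change in the chain and amine, so it gives no clean reading either.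

Going by the values given here, with no step bearing on the change, no step beyond the scatter is expected: compound 4 is estimated at 1300 nM (range 400 nM to 4500 nM), an expected step of a 1.3-fold higher number from compound 3 to compound 4 (0.12 log units; within the scatter) from compound 3, with wide uncertainty.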

Compound 4, half-maximal inhibitory concentration: 1210 nM
For compound 4 the middle estimate is 1.1-fold (0.03 log units) above the measured one; the measured number falls inside the stated range.
By their numbers in this assay, from the lowest: compounds 3, 4 and 2 (each within the scatter of the next); then compound 1.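

In this assay, among the compounds shown here, exchanging 3-(trifluoromethyl)phenyl for 3,4-difluorophenyl on the amide-type nitrogen gives a 1.2-fold higher number from compound 3 to compound 4 (0.09 log units; within the scatter), the first reading of an aryl exchange at this position on an otherwise fixed scaffold, and this position tolerates the exchange without a change beyond the scatter. With 3,4-difluorophenyl held fixed, the amine side chain now has two further single-place readings: (dimethylamino)methyl in place of dimethylamino gives a 3.0-fold lower number from compound 1 to compound 4 (0.48 log units; beyond the scatter), while (dimethylamino)methyl in place of diethylamino gives a 1.0-fold lower number from compound 2 to compound 4 (0.01 log units; within the scatter), so the extended dimethylamino chain and the diethylamino chain cannot be separated here, and each stands apart from the shorter dimethylamino chain of compound 1. No measurement available here accounts for either the aryl result or the chain result.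

For the compounds shown here, only two aryl groups have been compared at the amide-type nitrogen, so it remains open whether an unsubstituted phenyl or a pyridyl group would also stay within the scatter of these values. At the chain end, a morpholine or a pyrrolidine, or a still longer chain carrying dimethylamino, would test whether the values in this assay can move further.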